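Removing the butyl group from compound 1

This account rests on a few compounds, and the source may have more. Where it says the series, first, only, none or still open, it means among the compounds named here.

Measured so far in an ADME assay for pharmacokinetics; a higher number here means that the compound lasts longer, a lower number that the compound disappears faster:
compound 1 `CCCC[C@H]1CN(c2cccc(C)c2C)C(=O)CN1Cc1cncn1Cc1ccc(C#N)cc1` gives 0.6 h
compound 2 `N#Cc1ccc(Cn2cncc2CN2CCN(c3cccc(Cl)c3)CC2=O)cc1` gives 1.2 h

Compound 1 sits within the scatter of compound 2, so neither stands apart on these numbers. Next comes compound 3 `Cc1cccc(N2CCN(Cc3cncn3Cc3ccc(C#N)cc3)CC2=O)c1C` with the change (hydrogen in place of butyl on a saturated ring carbon), that is, hydrogen in place of butyl on a saturated ring carbon. Among the measured compounds shown here, no measured pair isolates this change. Compound 2 (1.2 h) also carries no butyl but differs elsewhere too, so only a small rise is expected, not clearly beyond the scatter: a 1.7-fold higher number from compound 1 to compound 3 (0.22 log units; within the scatter) (expected). For compound 3 the estimated value is 1 h (estimated range 0.5 h to 2.2 h).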

Compound 3, half-life in the ADME assay: 0.5 h
Beside the measured number, compound 3's estimate is 2.0-fold (0.30 log units) above it, and the stated range covers the measured number.
By their numbers in the ADME assay, from the lowest: compounds 3, 1 and 2 (each within the scatter of the next, the first and the last beyond it).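

Hydrogen in place of butyl on this saturated ring carbon is now isolated in one pair, and in the ADME assay it gives a 1.2-fold lower number from compound 1 to compound 3 (0.08 log units; within the scatter). In a physicochemical assay for lipophilicity (on this read-out lower numbers stand for lower lipophilicity and higher numbers for higher lipophilicity), the same change gives a number at least 1.70 log units lower from compound 1 to compound 3 (beyond the scatter), so the two read-outs do not move together across this pair. In the physicochemical assay compound 1 gives > 3.7, which is a limit of the assay and not a number. In the physicochemical assay compound 3 gives 2.

Going by these compounds, whether an ethyl chain, a longer chain or an amine on this ring carbon would stand apart from compound 3 in the ADME assay remains open.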